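Aryl swap on the saturated ring carbon: cytotoxicity notes

The source may report more compounds than this note shows. Statements on the series, on what has been measured and on what is new or still open speak of the compounds shown alone.

Measured compounds:
compound 1 `COc1cc(N2C(N)=C(C#N)C(c3ccc(OC)c4ccccc34)C3=C2CC(C)(C)CC3=O)cc(OC)c1OC` 40%
compound 2 `COc1cc(N2C(N)=C(C#N)C(c3cccs3)C3=C2CC(C)(C)CC3=O)cc(OC)c1OC` 20%

In a functional assay on Ehrlich cells (Mus musculus) for cytotoxicity, tested at 100 ug/mL (on this read-out higher numbers stand for a stronger effect at the one concentration tested and lower numbers for a weaker effect), compound 1 gives 40% and compound 2 gives 20%. Among the measured compounds shown here, compound 2 stands lowest of the two numbers so far, and its nearest neighbour is compound 1. For the measured compounds named here, the only measured step, a number 20 percentage points lower from compound 1 to compound 2 (beyond the scatter), is beyond the scatter.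

Compound 3 `COc1cc(N2C(N)=C(C#N)C(c3ccc(Cl)cc3Cl)C3=C2CC(C)(C)CC3=O)cc(OC)c1OC` is not yet measured. It differs from compound 2 in one place: 2,4-dichlorophenyl in place of thiophen-2-yl on a saturated ring carbon. Going by the values given here, the single step that bears on this change is the one that swaps the aryl group on the same saturated ring carbon, a number 20 percentage points lower from compound 1 to compound 2 (beyond the scatter); it shows that the group at this position shifts the read-out in this assay by a modest amount. Among the compounds with values here, with only one such step, and no measured example of a dichlorophenyl group at this position, the direction of the new step is uncertain; a modest move back toward the number of compound 1 is the working expectation, with a wide range on either side. For compound 3 the expected value is 30% with a range from 15% to 50%, an expected step of a number 10 percentage points higher from compound 2 to compound 3 (within the scatter).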

Compound 3, a percentage reported as activity, at one concentration (the size of the read-out at that concentration, not a potency): 100%
For compound 3 the middle estimate is 70 percentage points below the measured one; the whole stated range lies below it.
By their numbers in this assay, from the lowest: compound 2; then compound 1; then compound 3.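

In this assay the aryl group on this saturated ring carbon moves the read-out much further than the earlier step suggested: 2,4-dichlorophenyl in place of thiophen-2-yl gives a number 80 percentage points higher from compound 2 to compound 3 (beyond the scatter), and in place of 4-methoxynaphthalen-1-yl it gives a number 60 percentage points higher from compound 1 to compound 3 (beyond the scatter), both large steps. Compound 3 therefore stands above both earlier compounds, so this position can raise the read-out as well as lower it, and of the three groups the only one carrying chlorine sits at the top of the order. Nothing at hand accounts for the size of this change.

The compounds shown leave open whether the gain belongs to the phenyl ring itself or to its chlorines, and to which chlorine; plain phenyl, 2-chlorophenyl and 4-chlorophenyl would separate these cases. Also open, from the compounds shown here alone, is whether a phenyl ring bearing an amine or a carboxylic acid at this position stays near compound 3, and whether the order of the three compounds holds at lower concentrations, as a percentage at one concentration is not a potency.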